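Chloro to methyl on the benzamide ring of compound 1

The compounds below may be only part of what the source reports. "The series", "measured", "known", "first", "only" and "open" are said of these compounds alone.

Compound 1 `NC(=O)c1c(NC(=O)c2ccccc2Cl)sc2c1CCN(C(=S)Nc1ccccc1C(F)(F)F)C2` carries a ((2-chlorophenyl)carbonyl)amino group and a 2-(trifluoromethyl)phenyl on an amide-type nitrogen. Among the compounds with values here, in a functional assay on HeLa cells (Homo sapiens) for antiproliferative activity, with a stated time of 24 h (on this read-out higher numbers stand for weaker inhibition and lower numbers for stronger inhibition), compound 1 gives 26700 nM, which places it at the low end of the two numbers known, though only within the scatter. Compound 3 `COc1ccc(NC(=S)N2CCc3c(sc(NC(=O)c4ccccc4Cl)c3C(N)=O)C2)cc1` has 4-methoxyphenyl in place of 2-(trifluoromethyl)phenyl on that amide-type nitrogen and gives 36400 nM; the step of a 1.4-fold higher number from compound 1 to compound 3 (0.13 log units; within the scatter) stays within the scatter. Compound 2 `NC(=O)c1c(NC(=O)c2ccccc2Cl)sc2c1CCN(C(=S)Nc1ccc(C(F)(F)F)cc1)C2`, with 4-(trifluoromethyl)phenyl in that position, reaches only a limit of this assay, > 50000 nM. The step of an at least 1.8-fold higher number from compound 1 to compound 2 (0.27 log units; that floor lies within the scatter) is therefore only a floor, as is an at least 1.3-fold lower number from compound 2 to compound 3 (0.13 log units; that floor lies within the scatter).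

Compound 4 `Cc1ccccc1C(=O)Nc1sc2c(c1C(N)=O)CCN(C(=S)Nc1ccccc1C(F)(F)F)C2` differs from compound 1 elsewhere: methyl in place of chloro on an aromatic carbon. Within the data shown here, none of the measured steps touches this ring; all of them alter the aryl group on the amide-type nitrogen, and none moves the number beyond the scatter. Nothing among the known compounds speaks to the chloro-to-methyl exchange itself, so the account expects compound 4 to sit close to compound 1, with an expected step of a 1.0-fold higher number from compound 1 to compound 4 (0.02 log units; within the scatter) that remains within the scatter. The estimate for compound 4 in this assay is 28000 nM, expected to fall between 10000 nM and 80000 nM.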

Compound 4, half-maximal inhibitory concentration: > 50000 nM
Compound 4: only a limit was reported; the forecaster's own chance of this, stated with the estimate: 25%; at least 1.7-fold (0.25 log units) between middle value and limit.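

In this assay, within the data shown here, the exchange of chloro for methyl gives the first reading at this position of the shared core, as every earlier step had altered only the aryl group on the amide-type nitrogen: an at least 1.8-fold higher number from compound 1 to compound 4 (0.27 log units; that floor lies within the scatter). Compound 4 reaches only a limit of the assay, > 50000 nM, so this step is a floor, and since that floor lies within the scatter, the data do not establish that methyl reads differently from chloro here. What is new is that a single change on the (2-chlorophenyl)carbonyl group of compound 1 ends at the same limit as a single change on the aryl group did in compound 2: the limit of > 50000 nM in this assay, at which 2 of the 4 values shown sit.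

As far as these compounds go, the true size of the chloro-to-methyl step remains open, as does whether the exchange would read the same way with the 4-methoxyphenyl group of compound 3 on the amide-type nitrogen. With only chloro and methyl shown on this aromatic carbon, the compounds also leave open how a fluoro, a hydroxy or an amine would read there.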